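Sulfinamide to methylsulfoxide with added fluorine: expected shift

The compounds below may be only part of what the source reports. "The series", "measured", "known", "first", "only" and "open" are said of these compounds alone.

Of the compounds shown here, three sharing one core have been measured in a functional assay on CHO-K1 cells for agonist activity at Glucose-dependent insulinotropic receptor (Homo sapiens), read by a luciferase reporter, with a stated time of 5 h; on this read-out higher numbers stand for an effect only at larger amounts of compound and lower numbers for an effect already at smaller amounts. Compound 1 `CC(C)OC(=O)N1CCC(Oc2ncnc3c2CCN3c2ccc(S(C)(=O)=O)cc2)CC1` gives 126 nM. Compound 2 `CC(C)OC(=O)N1CCC(Oc2ncnc3c2CCN3c2ccc(S(C)(=O)=O)cn2)CC1` gives 126 nM, and no change at the digits printed from compound 1 to compound 2 (within the scatter). Compound 3 `CC(C)OC(=O)N1CCC(Oc2ncnc3c2CCN3c2ccc([S+]([O-])N(C)C)cc2)CC1` gives 501 nM, the highest of the three numbers; the step of a 4.0-fold higher number from compound 1 to compound 3 (0.60 log units; beyond the scatter) and the step of a 4.0-fold higher number from compound 2 to compound 3 (0.60 log units; beyond the scatter) both set it apart from the other two, beyond the scatter.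

Compound 4 `CC(C)OC(=O)N1CCC(Oc2ncnc3c2CCN3c2ccc([S@@+](C)[O-])c(F)c2)CC1` is not yet measured. It differs from compound 3 in one place: a group of 10 heavy atoms (7 carbon, 1 oxygen, 1 fluorine, 1 sulfur; one six-membered aromatic ring of carbon only) in place of a group of 11 heavy atoms (8 carbon, 1 nitrogen, 1 oxygen, 1 sulfur; one six-membered aromatic ring of carbon only), on a nitrogen on an aromatic ring in a ring. The group that leaves carries the sulfur bound to a nitrogen with two methyl groups; the group that enters carries the sulfur bound to a single methyl group, with a fluorine added to the ring.

The step that bears most directly on this change is a 4.0-fold higher number from compound 1 to compound 3 (0.60 log units; beyond the scatter), where a methylsulfonyl group was replaced by the dimethylsulfinamide and the number rose by a modest amount. The entering methylsulfoxide is closer in size to the methylsulfonyl of compound 1 than to the group it replaces, so the expectation is that the number falls back part of the way, giving a 2.5-fold lower number from compound 3 to compound 4 (0.40 log units; beyond the scatter). For the measured compounds named here, the added fluorine has no measured counterpart here, which widens the range. Compound 4 is therefore estimated at 200 nM, with a range from 60 nM to 700 nM.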

Compound 4, half-maximal effective concentration: 631 nM
Compound 4: the middle estimate sits 3.2-fold (0.50 log units) below what was measured, within the range that was stated.
By their numbers in this assay, from the lowest: compounds 1 and 2 (each within the scatter of the next); then compounds 3 and 4 (each within the scatter of the next).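

In this assay, replacing the dimethylsulfinamide-bearing ring group with the fluorinated methylsulfoxide-bearing one gives a 1.3-fold higher number from compound 3 to compound 4 (0.10 log units; within the scatter), so this change on the ring nitrogen does not separate the two compounds. The methylsulfonyl compounds remain apart from compound 4, with a 5.0-fold higher number from compound 1 to compound 4 (0.70 log units; beyond the scatter) and a 5.0-fold higher number from compound 2 to compound 4 (0.70 log units; beyond the scatter) showing that the new group sits with the dimethylsulfinamide of compound 3 and does not return the read-out to the level of compound 1 or compound 2. No measured information shown here accounts for this result.

Fluorine and the methylsulfoxide enter together in compound 4, which leaves open what each contributes alone and whether the opposite arrangement at its defined stereocentre would read the same. Also open, on these data alone, is how a nitrile or a primary carboxamide would compare with the sulfur-bearing groups when placed on this ring.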